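Adding a Nitrile to a Fluorophenyl Ether

This account rests on a few compounds, and the source may have more. Where it says the series, first, only, none or still open, it means among the compounds named here.

Three close relatives share one core and differ only in which fluorophenyl group sits on the oxygen. Compound 1 `CC(=O)N1CCCn2nc(COc3ccccc3F)cc21` gives 60% in a functional assay on HEK293 cells for positive allosteric modulation of metabotropic glutamate receptor 5 (Homo sapiens), read by calcium flux; a lower number here means a smaller maximal response, a higher number a larger maximal response. Compound 2 `CC(=O)N1CCCn2nc(COc3cccc(F)c3)cc21` gives 58% in this assay, and compound 3 `CC(=O)N1CCCn2nc(COc3ccc(F)cc3)cc21` gives 56%. Compound 2 thus stands second highest of the three numbers, but the distances are small: a number 2 percentage points lower from compound 1 to compound 2 (within the scatter), a number 2 percentage points lower from compound 2 to compound 3 (within the scatter), and likewise a number 4 percentage points lower from compound 1 to compound 3 (within the scatter). Swapping one fluorophenyl for another leaves the largest response essentially unchanged.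

Compound 4 `CC(=O)N1CCCn2nc(COc3cc(F)cc(C#N)c3)cc21` keeps the fluorine of compound 2 and carries one further group: cyano in place of hydrogen on an aromatic carbon. Going by the values given here, none of the measured steps adds a group; each only exchanges one fluorophenyl for another, and each stayed within the scatter. Among the compounds with values here, there is no measured step of the same kind to lean on. What the set does show is a flat response to small alterations on that ring. On that basis compound 4 is expected to stay close to compound 2, and the expected step is no change at the digits printed from compound 2 to compound 4 (within the scatter). The estimate for compound 4 in this assay is 58%, with an expected range from 40% to 76%. The range is kept wide; a cyano group is a new kind of change in this set.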

Compound 4, largest response reached (reported as percent of maximum), in percent of the reference or control that the assay uses: 39%
Beside the measured number, compound 4's estimate is 19 percentage points above it; the whole stated range lies above it.
By their numbers in this assay, from the lowest: compound 4; then compounds 3, 2 and 1 (each within the scatter of the next).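

Among compounds 1, 2 and 3, exchanging one fluorophenyl for another gave only steps within the scatter, so the ring looked insensitive to small alterations. Cyano in place of hydrogen on an aromatic carbon, meta to a fluoro group, breaks that picture: in this assay the step is a number 19 percentage points lower from compound 2 to compound 4 (beyond the scatter), the first step in this set to go beyond the scatter. The flat response therefore holds for exchanges among the fluorophenyl groups but does not extend to this added group of 2 heavy atoms, and no measurement at hand explains the drop in largest response.

Going by these compounds, whether a chlorine atom, a methyl group or a methoxy group on the same carbon would also lower the largest response remains open, and that would show whether the drop belongs to the cyano group or to any addition there. Also open, on these data alone, is whether a cyano group on another carbon of the ring, or on a ring without the fluorine, would give a similar number.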